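The source may report more compounds than this note shows. Statements on the series, on what has been measured and on what is new or still open speak of the compounds shown alone.

Compound 1 `O=S(=O)(c1ccc(-c2cnc(C3CC3)o2)cc1)N1CCc2ccccc21` is the parent of this small set, a sulfonamide whose saturated ring carries no substituent. In a functional assay on HCT-116 cells (Homo sapiens) for inhibition, read by MTT assay (on this read-out lower numbers stand for stronger inhibition and higher numbers for weaker inhibition), compound 1 gives 105 nM, the lowest number among the three compounds measured. Two single changes to compound 1 have already been tested. Compound 2 `CC1Cc2ccccc2N1S(=O)(=O)c1ccc(-c2cnc(C3CC3)o2)cc1` gives 14400 nM in this assay, and the step of a 140-fold higher number from compound 1 to compound 2 (2.14 log units; beyond the scatter) shows how strongly a methyl in place of hydrogen on a saturated ring carbon weakens inhibition. Compound 3 `Cc1ccc2c(c1)CCN2S(=O)(=O)c1ccc(-c2cnc(C3CC3)o2)cc1` gives 233 nM in this assay, and the step of a 2.2-fold higher number from compound 1 to compound 3 (0.35 log units; beyond the scatter) shows a far smaller loss for a methyl in place of hydrogen on an aromatic carbon.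

Compound 4 `O=[N+]([O-])c1ccc2c(c1)CCN2S(=O)(=O)c1ccc(-c2cnc(C3CC3)o2)cc1` differs from compound 1 by nitro in place of hydrogen on an aromatic carbon. The nitro group enters on an aromatic carbon, meta to a fused ring and para to a fused ring, so the step that bears most directly on it is the aromatic one, a 2.2-fold higher number from compound 1 to compound 3 (0.35 log units; beyond the scatter), not the large saturated one. A substituent on that aromatic ring has so far cost only a modest amount of potency, and a nitro group of three heavy atoms is expected to behave in the same modest way, giving an expected step of a 2.9-fold higher number from compound 1 to compound 4 (0.46 log units; beyond the scatter). Compound 4 is therefore estimated at 300 nM in this assay, with a range from 100 nM to 1200 nM.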

Compound 4, half-maximal inhibitory concentration: 1190 nM
For compound 4 the middle estimate is 4.0-fold (0.60 log units) below the measured one, within the range that was stated.
By their numbers in this assay, from the lowest: compound 1; then compound 3; then compound 4; then compound 2.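

In this assay, this aromatic carbon proves less forgiving than compound 3 alone suggested: the step of an 11-fold higher number from compound 1 to compound 4 (1.05 log units; beyond the scatter) is large, so a substituent here is not always cheap. Exchanging methyl for nitro on the same carbon gives a 5.1-fold higher number from compound 3 to compound 4 (0.71 log units; beyond the scatter), which shows that the outcome at this place depends on which group sits there, not merely on whether hydrogen has been replaced. Nothing available here explains why nitro costs more than methyl.

The compounds shown place only hydrogen, methyl and nitro on this carbon, so three groups are too few to reveal a trend, and it remains open whether the loss seen with nitro is particular to that group or shared by others. An amine, a methoxy group or a fluorine atom on the same aromatic carbon would help to settle this, since each could be compared directly with compound 1 and would show how widely the cost extends.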